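Swapping the halogen on the fused ring

The source may hold more compounds than are shown below. What is called first, only, known or untested is meant among the compounds shown, and "the series" means these compounds.

Compound 2 `COc1ccc(C2=NN(C3=NC(=O)/C(=C4\C(=O)Nc5ccc(Br)cc54)S3)C(c3ccc(OC)cc3)C2)cc1` stands lowest of the two numbers shown in a functional assay on cells (Cancer cell lines, Homo sapiens) for cytotoxicity, read by sulforhodamine B assay, with a stated time of 48 h (a lower number here means a stronger inhibitor of growth, a higher number a weaker inhibitor of growth), giving 200 nM. Its nearest neighbour is compound 1 `COc1ccc(C2=NN(C3=NC(=O)/C(=C4\C(=O)Nc5ccccc54)S3)C(c3ccc(OC)cc3)C2)cc1`, which carries hydrogen where compound 2 carries bromo, and in this assay compound 1 gives 85200 nM; the step of a 430-fold lower number from compound 1 to compound 2 (2.63 log units; beyond the scatter) is large. Compound 3 `COc1ccc(C2=NN(C3=NC(=O)/C(=C4\C(=O)Nc5ccc(Cl)cc54)S3)C(c3ccc(OC)cc3)C2)cc1` takes the next step: chloro in place of bromo on an aromatic carbon. Within the data shown here, only that one measured step bears on this change, and it shows that a halogen at this aromatic carbon matters greatly against hydrogen, yet nothing measured separates chloro from bromo. As both are single-heavy-atom halogens at the same place, compound 3 is expected to stay far closer to compound 2 than to compound 1, with at most a modest rise. The estimate for compound 3 is therefore 400 nM, within 100 nM to 3000 nM. That expected step, a 2.0-fold higher number from compound 2 to compound 3 (0.30 log units; within the scatter), is small.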

Compound 3, concentration for 50% growth inhibition: 190 nM
The estimate for compound 3 lay 2.1-fold (0.32 log units) above the measured number; low and high end bracket the measured number.
By their numbers in this assay, from the lowest: compounds 3 and 2 (each within the scatter of the next); then compound 1.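

In this assay the exchange of bromo for chloro on this aromatic carbon gives a 1.1-fold lower number from compound 2 to compound 3 (0.02 log units; within the scatter), so the two halogens cannot be told apart at this place. The change from hydrogen now has a second example: alongside a 430-fold lower number from compound 1 to compound 2 (2.63 log units; beyond the scatter) there stands a 450-fold lower number from compound 1 to compound 3 (2.65 log units; beyond the scatter), and so the large drop is not confined to bromo but is seen with chloro as well. No measurement shown explains why either halogen has so large an effect here. The compounds shown leave open whether this low range belongs to chloro and bromo alone or would also be reached with fluoro, iodo, methyl, methoxy or nitrile on this aromatic carbon. They also leave open whether the same halogen exchange would read the same way with other groups in place of the two methoxy-bearing rings.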